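Dihalophenyl in place of hydroxyphenyl: outlook for compound 4

The compounds below may be only part of what the source reports. "The series", "measured", "known", "first", "only" and "open" are said of these compounds alone.

The three measured compounds share one core and differ only in the aryl on the carbon with a double bond to nitrogen. Compound 1 `Cn1c(=O)c(=O)n(C2CCCC2)c2nc(N/N=C/c3ccc(F)c(Cl)c3)ncc21` carries 3-chloro-4-fluorophenyl, and in a functional assay on PC-3 cells (Homo sapiens) for antiproliferative activity, read by MTT assay (a lower number here means a stronger inhibitor, a higher number a weaker inhibitor), compound 1 gives 8550 nM. Compound 2 `COc1cccc(/C=N/Nc2ncc3c(n2)n(C2CCCC2)c(=O)c(=O)n3C)c1` carries 3-methoxyphenyl; in this assay compound 2 gives 20700 nM. Compound 3 `Cn1c(=O)c(=O)n(C2CCCC2)c2nc(N/N=C/c3cccc(O)c3)ncc21` carries 3-hydroxyphenyl, and in this assay compound 3 gives 36300 nM, the highest number of the three: a 1.8-fold higher number from compound 2 to compound 3 (0.24 log units; within the scatter), and a 4.2-fold higher number from compound 1 to compound 3 (0.63 log units; beyond the scatter).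

Compound 4 `Cn1c(=O)c(=O)n(C2CCCC2)c2nc(N/N=C/c3ccc(F)cc3Br)ncc21` is not yet measured. It differs from compound 3 by 2-bromo-4-fluorophenyl in place of 3-hydroxyphenyl on a carbon with a double bond to nitrogen. The step bearing most directly on this change is the one that traded a dihalogenated phenyl for the hydroxyphenyl, a 4.2-fold higher number from compound 1 to compound 3 (0.63 log units; beyond the scatter). The step of a 2.4-fold higher number from compound 1 to compound 2 (0.38 log units; beyond the scatter) likewise replaced that dihalophenyl with an oxygen-bearing aryl and went the same way. Within the data shown here, compound 4 restores a dihalogenated phenyl in this place, though not the same one as in compound 1, so no measured step covers the change exactly. For compound 4 a moderate lowering of the number is therefore expected, a 3.0-fold lower number from compound 3 to compound 4 (0.48 log units; beyond the scatter). For compound 4 the expected value in this assay is 12000 nM, with a range from 4500 nM to 35000 nM.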

Compound 4, half-maximal inhibitory concentration: 9250 nM
Compound 4: middle estimate off by 1.3-fold (0.11 log units), on the high side, and the stated range covers the measured number.
By their numbers in this assay, from the lowest: compounds 1 and 4 (each within the scatter of the next); then compounds 2 and 3 (each within the scatter of the next).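

In this assay, the lower numbers are not tied to the exact halogen pattern of compound 1: the 2-bromo-4-fluorophenyl group also separates from both oxygen-bearing aryls (a 3.9-fold lower number from compound 3 to compound 4 (0.59 log units; beyond the scatter); a 2.2-fold lower number from compound 2 to compound 4 (0.35 log units; beyond the scatter)). Exchanging 3-chloro-4-fluorophenyl for 2-bromo-4-fluorophenyl produces no change that can be told apart (a 1.1-fold higher number from compound 1 to compound 4 (0.03 log units; within the scatter)), so within this pair the place on the carbon with a double bond to nitrogen accepts a different halogen set and a different arrangement of halogens on the ring. Among these compounds, the four compounds now fall into a dihalophenyl pair and an oxygen-bearing pair with no compound going against that split, though it rests on only four aryl groups.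

Open, going by these compounds, is whether unsubstituted phenyl, a lone fluorine on the ring, or an amine or carboxylic acid on the aryl would sit with the dihalophenyl pair or with the oxygen-bearing pair. No accompanying measurement offers an explanation for the split between the two pairs.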